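Methylating the Phenol of a Dibromo Salicylanilide

This account rests on a few compounds, and the source may have more. Where it says the series, first, only, none or still open, it means among the compounds named here.

Compound 1 `O=C(Nc1cccc(Cl)c1)c1cc(Br)cc(Br)c1O`: > 100000 nM
Compound 2 `O=C(Nc1cccc(Cl)c1)c1cccc(Br)c1`: > 100000 nM
Compound 3 `COc1ccccc1C(=O)Nc1cccc(Cl)c1`: > 100000 nM

In an assay on isolated protein for inhibition of thiosulfate sulfurtransferase (Homo sapiens), with a stated time of 60 min, in the absence of a further agent (on this read-out lower numbers stand for stronger inhibition and higher numbers for weaker inhibition), compound 1 gives > 100000 nM, which is a limit of the assay and not a number. Compound 2 also reaches only a limit, > 100000 nM. Compound 3 likewise stops at a limit, > 100000 nM. Compound 1 therefore stands nowhere that can be ranked, since every value shown sits at the limit of > 100000 nM in this assay, at which 3 of the 3 values shown sit. Compound 4 `COc1c(Br)cc(Br)cc1C(=O)Nc1cccc(Cl)c1` differs from compound 1 by methyl in place of hydrogen on an oxygen on an aromatic ring. Within the data shown here, no step between measured compounds exists to guide the size of this change, so the step is expected to be a step that the limit leaves unreadable from compound 1 to compound 4, none beyond the scatter. Compound 4 is accordingly estimated at 150000 nM, between 40000 nM and 600000 nM, most likely again only a limit.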

Compound 4, half-maximal inhibitory concentration: > 100000 nM
Compound 4: only a limit was reported (the forecaster's own chance of this, stated with the estimate: 80%); the middle value is on the limit's open side.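

The step from compound 1 to compound 4 cannot be read, because both compounds stop at a limit: the limit of > 100000 nM in this assay, at which 4 of the 4 values shown sit. The compounds shown leave open whether going from hydroxy to methoxy changes inhibition at all.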